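Hepatocyte clearance notes: a bicyclic swap on the chloro series

The source may report more compounds than this note shows. Statements on the series, on what has been measured and on what is new or still open speak of the compounds shown alone.

Measured so far:
- compound 1, `CC(=O)N[C@@H]1CCC[C@H](C(=O)Nc2cc(-c3cnn4c3CCCC4)c(F)cn2)C1`: 73 uL/min
- compound 2, `CC(=O)N[C@@H]1CCC[C@H](C(=O)Nc2cc(-c3cnc4n3CCCC4)c(Cl)cn2)C1`: 12 uL/min

In an ADME assay on cells (Hepatocyte, Rattus norvegicus) for metabolic stability, using equilibrium dialysis (on this read-out lower numbers stand for slow clearance and higher numbers for fast clearance), compound 2 stands at the lower of the two numbers, and the value of compound 1 is beyond the scatter of it. Going by the values given here, compound 1 and compound 2 differ in more than one place, so no single step between them can be read off; only the two values themselves are known.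

Compound 3, `CC(=O)N[C@@H]1CCC[C@H](C(=O)Nc2cc(-c3cnn4c3NCCC4)c(Cl)cn2)C1`, is not yet measured in this assay. It keeps the chloro group of compound 2 and changes the neighbouring bicyclic group: a group of 9 heavy atoms (6 carbon, 3 nitrogen; one five-membered aromatic ring with 2 hetero atoms, one six-membered non-aromatic ring with 2 hetero atoms) in place of a group of 9 heavy atoms (7 carbon, 2 nitrogen; one five-membered aromatic ring with 2 hetero atoms, one six-membered non-aromatic ring with 1 hetero atom), on an aromatic carbon. The entering group carries one hydrogen-bond donor where the leaving group had none, and the five-membered aromatic ring of the entering group resembles that of compound 1, whose value in this assay is the higher of the two.

Among the compounds with values here, with no matched step available, the expectation is uncertain; a modest rise from compound 2 is estimated, as a 2.1-fold higher number from compound 2 to compound 3 (0.32 log units; beyond the scatter), since compound 1 gives 73 uL/min with a related aromatic ring. Compound 3 is estimated at 25 uL/min, within 9 uL/min to 70 uL/min.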

Compound 3, intrinsic clearance in a liver preparation (reported as CLH), per the amount of preparation that the assay uses: 10 uL/min
For compound 3 the middle estimate is 2.5-fold (0.40 log units) above the measured one; the measured number falls inside the stated range.
By their numbers in this assay, from the lowest: compounds 3 and 2 (each within the scatter of the next); then compound 1.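

In this assay the exchange of bicyclic groups gives a 1.2-fold lower number from compound 2 to compound 3 (0.08 log units; within the scatter), so on an aromatic carbon ortho to a chloro group the two groups cannot be told apart on this read-out. The entering group, with its hydrogen-bond donor and its six-membered non-aromatic ring with 2 hetero atoms, therefore carries no clearance penalty that can be read in the chloro series, at least for this single pair. Nothing available explains why the two groups read alike.

As far as these compounds go, compound 1 differs from compound 2 and from compound 3 in more than one place, so its steps to them cannot be read, and what a fluoro group would do in place of the chloro group alongside either bicyclic group stays open. Also open, from the compounds shown here alone, is how this position would respond to a carboxylic acid or a longer chain on the six-membered non-aromatic ring, or to a methyl group on the nitrogen that carries the hydrogen-bond donor.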